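Lengthening the side chain of compound 3

The source may report more compounds than this note shows. Statements on the series, on what has been measured and on what is new or still open speak of the compounds shown alone.

Measured in an ADME assay on microsomes from liver (Rattus norvegicus, strain Sprague-Dawley) for metabolic stability, read by LC-MS, using NADPH, with a stated time of 60 min, tested at 10 mM; a higher number here means that more of the compound is left, a lower number that less of the compound is left:
- compound 1 `O=Cc1c(-c2nc(NCCCCN3CCCC3)c3ccccc3n2)[nH]c2ccccc12`: 83.9%
- compound 2 `CCN(CC)CCCCNc1nc(-c2[nH]c3ccc(OC)cc3c2C=O)nc2ccccc12`: 84%
- compound 3 `COc1ccc2[nH]c(-c3nc(NCCN4CCCC4)c4ccccc4n3)c(C=O)c2c1`: 66.6%

Compound 3 stands lowest of the three, with compound 1 and compound 2 both higher by more than the usual scatter. Compound 4 `COc1ccc2[nH]c(-c3nc(NCCCCN4CCCC4)c4ccccc4n3)c(C=O)c2c1` differs from it in one place, on a saturated chain carbon, two bonds along the chain from a nitrogen on an aromatic ring: 2-(pyrrolidin-1-yl)ethyl in place of pyrrolidin-1-yl on a saturated chain carbon, two bonds along the chain from a nitrogen on an aromatic ring. Going by the values given here, one measured step bears on this change at the same place, a modest one: a number 17.4 percentage points lower from compound 2 to compound 3 (beyond the scatter). It came with pyrrolidin-1-yl in place of 2-(diethylamino)ethyl. Compound 1 also carries 4-(pyrrolidin-1-yl)butyl and gives 83.9%. An upward step of similar size, beyond the scatter, is therefore expected: a number 15.4 percentage points higher from compound 3 to compound 4 (beyond the scatter). For compound 4 the estimated value is 82%, within an expected range from 70% to 93%.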

Compound 4, percent of the compound remaining: 80.7%
Beside the measured number, compound 4's estimate is 1.3 percentage points above it, within the range that was stated.
By their numbers in this assay, from the lowest: compound 3; then compounds 4, 1 and 2 (each within the scatter of the next).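

In this assay, going by these compounds alone, 2-(pyrrolidin-1-yl)ethyl in place of pyrrolidin-1-yl gives a number 14.1 percentage points higher from compound 3 to compound 4 (beyond the scatter), the first step here that changes only the chain length while keeping the pyrrolidine ring. With the longer chain, neither the end group nor the methoxy shifts the number beyond the scatter: pyrrolidin-1-yl in place of diethylamino gives a number 3.3 percentage points lower from compound 2 to compound 4 (within the scatter), and methoxy in place of hydrogen gives a number 3.2 percentage points lower from compound 1 to compound 4 (within the scatter). No measurement here gives a reason for these results. The compounds shown leave open how a chain of intermediate length, 3-(pyrrolidin-1-yl)propyl, would behave, and whether a morpholine at the chain end would fit the same picture.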